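Adding Chloro to the Phenylpiperazine of Compound 3

The compounds below may be only part of what the source reports. "The series", "measured", "known", "first", "only" and "open" are said of these compounds alone.

Compound 3 `COc1ccc(-c2nnc(N3CCN(C(=O)CN4CCN(c5ccccc5)CC4)CC3)nc2-c2ccc(OC)cc2)cc1` is the starting point. In an ADME assay on NIH3T3 cells (Mus musculus) for cytotoxicity, read by MTT assay, with a stated time of 24 h (a higher number here means a weaker inhibitor, a lower number a stronger inhibitor), compound 3 reaches only > 863000 nM, which is a limit of the assay rather than a number, so it sits at the limit of > 863000 nM in this assay, at which 1 of the 3 values shown sits. Its shared core is the same as in compound 1 `O=C(CN1CCN(c2ccccc2)CC1)N1CCN(c2nnc(-c3ccccc3)c(-c3ccccc3)n2)CC1`. Compound 1 also gives a limit, > 963000 nM, in this assay. Compound 2 `O=C(CN1CCN(c2ccccc2Cl)CC1)N1CCN(c2nnc(-c3ccccc3)c(-c3ccccc3)n2)CC1`, which carries chloro in place of hydrogen on an aromatic carbon, gives 350000 nM in this assay. For the measured compounds named here, the step of an at least 2.7-fold lower number from compound 1 to compound 2 (0.43 log units; beyond the scatter) is the one piece of evidence on the kind of change now considered.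

Compound 4 `COc1ccc(-c2nnc(N3CCN(C(=O)CN4CCN(c5cccc(Cl)c5)CC4)CC3)nc2-c2ccc(OC)cc2)cc1` differs from compound 3 by chloro in place of hydrogen on an aromatic carbon. Going by the values given here, since the only comparable step is an at least 2.7-fold lower number from compound 1 to compound 2 (0.43 log units; beyond the scatter), a number lower than the limit seen for compound 3 is expected for compound 4, in the direction of stronger inhibition, though with a single precedent the size is uncertain and the outcome may again be a limit. The step of an at least 1.9-fold lower number from compound 3 to compound 4 (0.28 log units; that floor lies within the scatter) is the one expected. Compound 4 is thus estimated at 450000 nM in this assay, with a range from 150000 nM to 1500000 nM.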

Compound 4, half-maximal inhibitory concentration: > 814000 nM
Compound 4: no number, only a limit (the forecaster's own chance of this, stated with the estimate: 45%); middle value at least 1.8-fold (0.25 log units) away from the limit.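

In this assay compound 4 gives > 814000 nM, which is a limit of the assay and not a number. For the compounds shown here, compound 3 also stands at a limit, > 863000 nM, so no step between compound 3 and compound 4 can be read. The compounds shown leave open whether chloro in place of hydrogen on compound 3 gives anything like the earlier step, an at least 2.7-fold lower number from compound 1 to compound 2 (0.43 log units; beyond the scatter).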